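The source may hold more compounds than are shown below. What is called first, only, known or untested is meant among the compounds shown, and "the series" means these compounds.

Measured so far:
compound 1, `CCOC(=O)c1ccc(N/C(=N\C#N)NCc2ccncc2)cc1`, 41400 nM
compound 2, `O=C(NCc1ccncc1)Nc1ccc(S(=O)(=O)N2CC3CCC(C2)O3)cc1`, 279 nM
compound 3, `O=C(NCc1cn[nH]c1)Nc1ccc(S(=O)(=O)c2ccc(Cl)cc2)cc1`, 23 nM

In an assay on isolated protein for activation of Nicotinamide phosphoribosyltransferase (Homo sapiens) (on this read-out higher numbers stand for an effect only at larger amounts of compound and lower numbers for an effect already at smaller amounts), compound 2 stands second highest of the three numbers: compound 3 gives a clearly lower number and compound 1 a far higher one, and both gaps lie beyond the scatter of repeated measurements. The next compound, compound 4, `CCN(CC)S(=O)(=O)c1ccc(NC(=O)NCc2ccncc2)cc1`, keeps the core of compound 2 and changes only one part: a group of 5 heavy atoms (4 carbon, 1 nitrogen; no ring) in place of a group of 8 heavy atoms (6 carbon, 1 nitrogen, 1 oxygen; one five-membered non-aromatic ring with 1 hetero atom, one six-membered non-aromatic ring with 2 hetero atoms), on a sulfonyl sulfur. Among the measured compounds shown here, no measured pair shows this kind of exchange, so its effect is unknown. The exchange is expected to move this assay by a small step upward, with the step from compound 2 to compound 4 estimated at a 1.8-fold higher number from compound 2 to compound 4 (0.25 log units; within the scatter), close to the scatter. Compound 4 is therefore estimated at 500 nM, with a range from 150 nM to 2000 nM.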

Compound 4, half-maximal effective concentration: 384 nM
Compound 4: the middle estimate sits 1.3-fold (0.11 log units) above what was measured; low and high end bracket the measured number.
By their numbers in this assay, from the lowest: compound 3; then compounds 2 and 4 (each within the scatter of the next); then compound 1.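

In this assay, a 1.4-fold higher number from compound 2 to compound 4 (0.14 log units; within the scatter), so on this sulfonyl sulfur, the two-ring group and open-chain diethylamino cannot be told apart. For this pair, neither the rings nor the ring oxygen is needed to keep the number at this level. No measurement shown explains this result.

On these data alone, it remains open how far this tolerance extends: a much smaller dimethylamino group, or a chain ending in a carboxylic acid or a primary amine, could behave differently. One pair cannot show whether the same exchange would behave alike on another core.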